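A few compounds are considered here, and "the series" means these few. Any claim that something is new, unique, unknown or untested is made for them only; others in the source may bear on it.

Two compounds built on the shared core of compound 1 `O=C(CCC(=O)OCCCCCCSc1ccc([N+](=O)[O-])c2nonc12)Nc1ccccc1` have been measured in an ADME assay on HUVEC cells (Homo sapiens) for cytotoxicity, read by MTT assay, with a stated time of 72 h; a higher number here means a weaker inhibitor, a lower number a stronger inhibitor. In this assay compound 1 gives 2490 nM, and compound 2 `O=C(CCC(=O)OCCCCCCSc1ccc([N+](=O)[O-])c2nonc12)Nc1ccc(Br)cc1` gives 1610 nM. Among the measured compounds shown here, the only step between them, a 1.5-fold lower number from compound 1 to compound 2 (0.19 log units; within the scatter), lies within the scatter, so on the two numbers available compound 2 is not separated from compound 1; it simply stands nearest to it.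

Compound 3 `COc1ccc(NC(=O)CCC(=O)OCCCCCCSc2ccc([N+](=O)[O-])c3nonc23)cc1` differs from compound 2 in one place: methoxy in place of bromo on an aromatic carbon. For the measured compounds named here, no measured step exchanges bromo for methoxy. Going by the values given here, the single step that bears on this part of the molecule at all, a 1.5-fold lower number from compound 1 to compound 2 (0.19 log units; within the scatter), concerns bromo entering for hydrogen, not methoxy for bromo, and was itself within the scatter. There is therefore no ground in the data to expect a step beyond the scatter in this assay, in either direction. The step that this estimate means, a 1.2-fold higher number from compound 2 to compound 3 (0.09 log units; within the scatter), is expected to be small. Compound 3 is expected to give about 2000 nM in this assay, with an estimated range from 900 nM to 4500 nM.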

Compound 3, half-maximal inhibitory concentration: 1590 nM
Beside the measured number, compound 3's estimate is 1.3-fold (0.10 log units) above it, within the range that was stated.
By their numbers in this assay, from the lowest: compounds 3, 2 and 1 (each within the scatter of the next).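

In this assay, exchanging bromo for methoxy on this aromatic carbon swaps one heavy atom for two and adds one hydrogen-bond acceptor, yet the result is only (a 1.0-fold lower number from compound 2 to compound 3 (0.01 log units; within the scatter)), so the assay does not separate the two groups at this position. Methoxy set against hydrogen, the comparison that the earlier compounds could not offer, also stays small (a 1.6-fold lower number from compound 1 to compound 3 (0.19 log units; within the scatter)), as did the earlier bromo step (a 1.5-fold lower number from compound 1 to compound 2 (0.19 log units; within the scatter)), which means that hydrogen, bromo and methoxy, on this carbon para to a large group, all lie within the scatter of one another in the three compounds shown. Nothing available here offers an explanation for this result.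

Three compounds cannot show whether this position would stay as unresponsive with groups of another kind on the same carbon, such as an amine, a carboxylic acid or a longer chain. They also leave open whether the readings in this assay would shift if the parts of the molecule outside this aromatic ring were changed, since all three share the rest of the core of compound 1.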